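Pyrimidine for pyridine on the diarylamine nitrogen

This account rests on a few compounds, and the source may have more. Where it says the series, first, only, none or still open, it means among the compounds named here.

Compound 2 `O=c1cc(CN(c2cccnc2)c2cccc(Cl)c2)c2ccc(F)c(F)c2[nH]1` is the stronger of the two measured compounds in an assay on HEK293 cells for inhibition of Nitric oxide synthase, inducible (Homo sapiens), read by fluorescence (a higher number here means a weaker inhibitor, a lower number a stronger inhibitor), where compound 2 gives 77 nM. Going by the values given here, its nearest neighbour is compound 1 `O=c1cc(CN(c2ccccc2)c2cccc(Cl)c2)c2ccc(F)c(F)c2[nH]1`, which in this assay gives 1500 nM; the only measured step, a 19-fold lower number from compound 1 to compound 2 (1.29 log units; beyond the scatter), is large and beyond the scatter.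

Compound 3 `O=c1cc(CN(c2cccc(Cl)c2)c2ccncn2)c2ccc(F)c(F)c2[nH]1` is not yet measured. It differs from compound 2 in one place: pyrimidin-4-yl in place of pyridin-3-yl on a nitrogen on an aromatic ring. Among the compounds with values here, the single step that bears on this change is a 19-fold lower number from compound 1 to compound 2 (1.29 log units; beyond the scatter), which shows that exchanging phenyl for a six-membered aromatic ring with one nitrogen on this nitrogen gave a much lower number. The present change again alters the same aryl group, but swaps one nitrogen-containing ring for another rather than introducing the first ring nitrogen, so a step of the same size is not assumed. On this basis compound 3 is expected to land near compound 2, with the estimated step of a 1.3-fold higher number from compound 2 to compound 3 (0.11 log units; within the scatter) judged to lie within or only modestly beyond the scatter in either direction. The estimate for compound 3 in this assay is 100 nM, with a range from 25 nM to 400 nM.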

Compound 3, half-maximal inhibitory concentration: 14 nM
Compound 3: middle estimate off by 7.1-fold (0.85 log units), on the high side; the whole stated range lies above it.
By their numbers in this assay, from the lowest: compound 3; then compound 2; then compound 1.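

In this assay, this aryl position on the nitrogen still responds after the first ring nitrogen is in place: pyrimidin-4-yl in place of pyridin-3-yl gives a 5.5-fold lower number from compound 2 to compound 3 (0.74 log units; beyond the scatter), so the gain seen on leaving phenyl is not confined to that first exchange. Measured against the phenyl compound, pyrimidin-4-yl gives a 110-fold lower number from compound 1 to compound 3 (2.03 log units; beyond the scatter), and across these three compounds the number falls as the hetero atoms in this ring go up from none to one to two, with none of compound 1, compound 2 or compound 3 going against that order. No measurement at hand bears on why this ring exchange lowers the number.

Compound 2 and compound 3 differ both in the count of ring nitrogens and in the ring's naming as a 3-yl or a 4-yl group, so these compounds cannot separate the second ring nitrogen from its placement. Isomeric rings such as pyrimidin-5-yl or pyrazin-2-yl, or a small group such as an amine or a methoxy on the pyrimidin-4-yl ring, would test how specific this aryl group is.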